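A few compounds are considered here, and "the series" means these few. Any claim that something is new, unique, unknown or untested is made for them only; others in the source may bear on it.

Three compounds have been measured in an assay on HEK293 cells for agonist activity at transient receptor potential cation channel subfamily M member 8 (Homo sapiens), read by fluorescence and calcium flux, with a stated time of 15 min; a higher number here means that more compound is needed for the effect, a lower number that less compound is needed:

compound 1, `CCN(Cc1cccs1)C(=O)c1cc2cc(C)ccc2o1`, gives 120 nM
compound 2, `CCN(Cc1cccn1C)C(=O)COc1ccc(C)cc1`, gives 21300 nM
compound 3, `Cc1ccc(OCC(=O)N(Cc2cccs2)C2CCCCC2)cc1`, gives 40000 nM

Compound 3 has the highest number of the three. Its value and that of compound 2 lie within the usual scatter, so the two cannot be told apart, while the gap to compound 1 is far beyond the scatter. Compound 4, `COCCN(Cc1cccs1)C(=O)COc1ccc(C)cc1`, is not yet measured. It differs from compound 3 in one place: 2-methoxyethyl in place of cyclohexyl on an amide-type nitrogen. Compound 2 also carries a short group on its amide-type nitrogen, so a step of this size is not expected to move the number far. The step of a 2.2-fold lower number from compound 3 to compound 4 (0.35 log units; beyond the scatter) is expected to be small, towards a lower number but hardly beyond the scatter. Compound 4 is estimated at 18000 nM, within a range from 5000 nM to 60000 nM.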

Compound 4, half-maximal effective concentration: 400 nM
The estimate for compound 4 lay 45-fold (1.65 log units) above the measured number; the whole stated range lies above it.
By their numbers in this assay, from the lowest: compound 1; then compound 4; then compounds 2 and 3 (each within the scatter of the next).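

In this assay, the group on the amide-type nitrogen proves to matter greatly: 2-methoxyethyl in place of cyclohexyl gives a 100-fold lower number from compound 3 to compound 4 (2.00 log units; beyond the scatter). Among the compounds shown here, this is the first measured pair differing in one place, so it isolates this position and shows that a change here alone can produce a large step. Nothing available explains the size of this step.

The change removes a ring and adds an oxygen together, and the compounds shown cannot separate the two. Also open, on these data alone, is how a plain butyl chain or a chain ending in an amine would behave here.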